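Extending the side chain with a urea group

The compounds below may be only part of what the source reports. "The series", "measured", "known", "first", "only" and "open" are said of these compounds alone.

Measured so far:
- compound 1, `Cc1nc(NCC(C)C)nc(N[C@@H]2C[C@H](CO)[C@@H](O)[C@H]2O)c1-c1nc2ccccc2s1`: 10000 nM
- compound 2, `COCCNc1nc(C)c(-c2nc3ccccc3s2)c(N[C@@H]2C[C@H](CO)[C@@H](O)[C@H]2O)n1`: 21000 nM

In an ADME assay on cells (Homo sapiens) for cytotoxicity, read by polymerase chain reaction, with a stated time of 3 days (on this read-out higher numbers stand for lower toxicity in this test and lower numbers for higher toxicity in this test), compound 2 gives 21000 nM, the higher of the two numbers; compound 1 gives 10000 nM, and a 2.1-fold higher number from compound 1 to compound 2 (0.32 log units; beyond the scatter). Compound 3, `Cc1nc(NCCNC(=O)NC(C)(C)C)nc(N[C@@H]2C[C@H](CO)[C@@H](O)[C@H]2O)c1-c1nc2ccccc2s1`, carries ((tert-butyl)carbamoyl)amino in place of methoxy on a saturated chain carbon, two bonds along the chain from a nitrogen on an aromatic ring. Among the compounds with values here, only the step from compound 1 to compound 2 touches this chain, and it was modest; the new group is larger and not directly mirrored by any measured step. Compound 3 is therefore expected to show a 1.1-fold lower number from compound 2 to compound 3 (0.02 log units; within the scatter), no step beyond the scatter. The estimate for compound 3 is 20000 nM, ranging from 8000 nM to 50000 nM.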

Compound 3, half-maximal cytotoxic concentration: > 25000 nM
Compound 3: only a limit was reported; the forecaster's own chance of this, stated with the estimate: 25%; at least 1.2-fold (0.09 log units) between middle value and limit.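

The value of compound 3 is a limit, not a number: the limit of > 25000 nM in this assay, at which 1 of the 3 values shown sits. Putting ((tert-butyl)carbamoyl)amino in place of methoxy gives an at least 1.1-fold higher number from compound 2 to compound 3 (0.07 log units; that floor lies within the scatter), so this larger group on the chain brought no sign of higher toxicity in this test. Compared with the isopropyl end of compound 1, the change gives an at least 2.5-fold higher number from compound 1 to compound 3 (0.39 log units; beyond the scatter), which extends the modest earlier gain on this chain.

As far as these compounds go, how far compound 3 lies past its limit remains open. So does how a primary amine or a carboxylic acid on this chain would read.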